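The source may hold more compounds than are shown below. What is called first, only, known or untested is meant among the compounds shown, and "the series" means these compounds.

Measured so far in this series:
compound 1, `CCCCCCNc1nc(-c2ccccc2)nc2c1nnn2Cc1ccccc1Cl` — 31 nM
compound 2, `CCCCCCNc1nc(-c2ccccc2)nc2c1nnn2Cc1ccccc1F` — 25 nM

In an assay on Cerebral cortex for displacement of a labelled ligand from adenosine receptor A1 (Bos taurus) (a higher number here means a weaker inhibitor, a lower number a stronger inhibitor), compound 1 gives 31 nM, the higher of the two numbers shown; compound 2 gives 25 nM. Among the compounds with values here, the only measured step, a 1.2-fold lower number from compound 1 to compound 2 (0.09 log units; within the scatter), is within the scatter, so the two halogens on the aromatic carbon cannot be told apart on these numbers.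

Compound 3, `OCCNc1nc(-c2ccccc2)nc2c1nnn2Cc1ccccc1Cl`, differs from compound 1 by hydroxy in place of butyl on a saturated chain carbon, two bonds along the chain from a nitrogen on an aromatic ring. Within the data shown here, no measured step bears on this change: the one step available concerns the aromatic halogen, not the chain on the ring nitrogen. The change itself is large, taking four heavy atoms out of the chain and putting in a hydroxy, so the estimate is set for a weaker number than compound 1, with a wide range. The expected step is a 13-fold higher number from compound 1 to compound 3 (1.11 log units; beyond the scatter). For compound 3 the estimate in this assay is 400 nM, between 60 nM and 3000 nM.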

Compound 3, inhibition constant: 116 nM
Beside the measured number, compound 3's estimate is 3.4-fold (0.54 log units) above it, and the stated range covers the measured number.
By their numbers in this assay, from the lowest: compounds 2 and 1 (each within the scatter of the next); then compound 3.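

In this assay the series now has its first step beyond the scatter: going from hexylamino to (2-hydroxyethyl)amino gives a 3.7-fold higher number from compound 1 to compound 3 (0.57 log units; beyond the scatter) and marks this chain as a place where the number responds to change, unlike the aromatic halogen swap. The step is modest even though butyl leaves and hydroxy enters, so this position accepts a much shorter chain ending in hydroxy with only a limited rise in the number. Nothing available explains the rise, and the data cannot separate the loss of butyl from the entry of hydroxy.

An unsubstituted ethyl chain would separate those two parts, while a longer chain ending in hydroxy would show how chain length acts with the hydroxy kept. From the compounds shown here alone, an amine or a carboxylic acid at the chain end remains open, as does whether fluoro in place of chloro stays within the scatter on the 2-hydroxyethyl chain.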